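A few compounds are considered here, and "the series" means these few. Any claim that something is new, unique, unknown or untested is made for them only; others in the source may bear on it.

Compound 1, `COc1c(OCc2cnoc2C)cc(O)c2c(=O)cc(-c3ccccc3)oc12`, was tested in a functional assay on A549 cells (Homo sapiens) for cytotoxicity, read by MTT assay, with a stated time of 48 h; a lower number here means a stronger inhibitor, a higher number a weaker inhibitor. In this assay compound 1 gives > 100000 nM, which is a limit of the assay rather than a measured number. Compound 1 therefore stands at the edge of what the assay can report, a position shared by every other value seen here, (the limit of > 100000 nM in this assay, at which 2 of the 2 values shown sit). Compound 2, `CN1CCN(CCCCOc2c(O)cc(O)c3c(=O)cc(-c4ccccc4)oc23)CC1`, is built on the same core. In this assay compound 2 gives > 100000 nM, again a limit and not a number. Compound 3, `CCN(CC)CCCOc1cc(O)c2c(=O)cc(-c3ccccc3)oc2c1OC`, has not yet been tested. It differs from compound 1 in one place: 2-(diethylamino)ethyl in place of 5-methyl-1,2-oxazol-4-yl on a saturated chain carbon bound to an oxygen on an aromatic ring. Among the measured compounds shown here, no measured pair shows how such a change moves this assay, and with both known values sitting at the limit there is nothing to suggest a shift beyond the usual scatter, so the step is expected to be a number no higher from compound 1 to compound 3 (the limit leaves the size open). Compound 3 is accordingly estimated at 100000 nM, within 30000 nM to 300000 nM, and is most likely to be reported once more only as a limit.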

Compound 3, half-maximal inhibitory concentration: 1830 nM
The estimate for compound 3 lay 55-fold (1.74 log units) above the measured number, and the stated range ends above it.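

In this assay, putting 2-(diethylamino)ethyl in place of 5-methyl-1,2-oxazol-4-yl, on a saturated chain carbon bound to an oxygen on an aromatic ring, gives an at least 54-fold lower number from compound 1 to compound 3 (1.73 log units; beyond the scatter). Among the compounds shown here, this shows that the group at this position can matter a great deal on the shared core, something the earlier compounds could not show while both sat at the limit of the assay. Compound 3 is the only compound here with a real number, and the others offer only a limit: the limit of > 100000 nM in this assay, at which 2 of the 3 values shown sit.

The change removes a ring and brings in an open chain with an amine, so the compounds shown cannot tell which of these matters. From the compounds shown here alone, it also remains open whether a shorter or longer chain, or another amine such as morpholine or dimethylamino, would give a similar number.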